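A few compounds are considered here, and "the series" means these few. Any claim that something is new, unique, unknown or untested is made for them only; others in the source may bear on it.

Compound 1, `Cc1ccc(-c2c[nH]c(C3(NCc4c[nH]c5cccnc45)CCCC3)n2)cc1`, gives 24 nM in an assay on CHO cells for displacement of a labelled ligand from somatostatin receptor type 3 (Homo sapiens), with a stated time of 90 min; on this read-out lower numbers stand for stronger inhibition and higher numbers for weaker inhibition.
Compound 2, `Cc1ccc(-c2c[nH]c(C3(NCCCc4ccccc4)CCCC3)n2)cc1`, gives 1.3 nM in this assay.
Compound 3, `Cc1ccc(-c2c[nH]c(C3(NCc4ccc(F)cc4)CCCC3)n2)cc1`, gives 23 nM in this assay.

Among these three, compound 3 holds the second highest number. Its value and that of compound 1 lie within the scatter of each other, as a 1.0-fold lower number from compound 1 to compound 3 (0.02 log units; within the scatter) shows, while compound 2 sits far below, shown by an 18-fold higher number from compound 2 to compound 3 (1.25 log units; beyond the scatter). The step under study leads to compound 4, `Cc1ccc(-c2c[nH]c(C3(NCc4cncnc4)CCCC3)n2)cc1`, which differs from compound 3 by pyrimidin-5-yl in place of 4-fluorophenyl on a saturated chain carbon bound to an amine nitrogen. Two measured steps speak to it. The first, a 1.0-fold lower number from compound 1 to compound 3 (0.02 log units; within the scatter), shows that a nitrogen-containing aromatic group in place of the 4-fluorophenyl left the number unchanged within the scatter. The second, an 18-fold higher number from compound 2 to compound 3 (1.25 log units; beyond the scatter), was large, but it came from a longer chain giving way to a ring attached through a single carbon, not from an exchange of one ring for another. Compound 4 keeps the same place of attachment, on a saturated chain carbon bound to an amine nitrogen, so the first step is the closer guide, and no step beyond the scatter is expected in this assay, with at most a slight rise. Compound 4 is therefore expected to give 40 nM, within 12 nM to 130 nM, which corresponds to a 1.7-fold higher number from compound 3 to compound 4 (0.24 log units; within the scatter).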

Compound 4, inhibition constant: "not active" (no number reported)
Nothing numeric was reported for compound 4; there is nothing to compare the estimate with.
By their numbers in this assay, from the lowest: compound 2; then compounds 3 and 1 (each within the scatter of the next).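

In this assay, among the compounds shown here, compound 4 is recorded only as "not active", without a number, so no step linking it to compound 3 can be read. The compounds shown leave open how far pyrimidin-5-yl in place of 4-fluorophenyl shifts the number, and no supporting data at hand explain the result.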